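The source may hold more compounds than are shown below. What is called first, only, known or untested is meant among the compounds shown, and "the series" means these compounds.

In a functional assay on MDA-MB-231 cells (Homo sapiens) for cytotoxicity, with a stated time of 48 h (a higher number here means a weaker inhibitor, a lower number a stronger inhibitor), compound 2 `COc1cc(O)c(C(=O)/C=C/c2ccccc2OC)c(OC)c1` gives > 20000 nM, which is a limit of the assay and not a number.

Compound 3 `COc1cc(O)c(C(=O)/C=C/c2ccccc2SC)c(OC)c1` keeps everything in compound 2 except one group: methylsulfanyl in place of methoxy on an aromatic carbon, ortho to a large group (methylsulfanyl in place of methoxy on an aromatic carbon).

Within the data shown here, no pair of measured compounds differs in one place only, so there is no direct precedent for the size of this change. Among the measured compounds shown here, the only firm number comes from compound 1 `COc1cc(OC)c(C(=O)/C=C/c2ccccc2SC)c(OC)c1`, which also carries methylsulfanyl and gives 9900 nM in this assay. On that single value, the expected change an at least 2.0-fold lower number from compound 2 to compound 3 (0.30 log units; that floor lies within the scatter) points towards a lower number, meaning a stronger inhibitor, though its size is uncertain with a limit as the starting point.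

For compound 3 the estimated value is 10000 nM, with an expected range of 3500 nM to 25000 nM.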

Compound 3, half-maximal inhibitory concentration: > 20000 nM
Compound 3 ended at the assay's limit (the forecaster's own chance of this, stated with the estimate: 25%); middle value at least 2.0-fold (0.30 log units) away from the limit.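

In this assay compound 3 gives > 20000 nM, which is a limit of the assay and not a number. Among these compounds, the one step that can be read is a different change, hydrogen in place of methyl on an oxygen on an aromatic ring, and it shows an at least 2.0-fold higher number from compound 1 to compound 3 (0.30 log units; that floor lies within the scatter); so methylsulfanyl at this position does not by itself give a value inside the range of the assay. The step from methoxy to methylsulfanyl cannot be read, since compound 2 and compound 3 both end at the same limit: the limit of > 20000 nM in this assay, at which 2 of the 3 values shown sit.

As far as these compounds go, whether methylsulfanyl and methoxy differ at all at this position stays open, as neither compound has a true number. Also open, from the compounds shown here alone, is how an amine or a longer chain at this position would read in this assay.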